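Moving the two fluorines on a difluorophenyl amide

This account rests on a few compounds, and the source may have more. Where it says the series, first, only, none or still open, it means among the compounds named here.

Compound 1 `CN(C(=O)NC(=O)c1ccc(F)c(F)c1)c1nc(C(F)(F)F)c(C(=O)N/N=C/c2ccc(C(F)(F)F)cc2)s1`, compound 2 `CN(C(=O)NC(=O)c1ccc(F)c(F)c1)c1nc(C(F)(F)F)c(C(=O)N/N=C/c2ccccc2C(F)(F)F)s1` and compound 3 `CN(C(=O)NC(=O)c1ccc(F)c(F)c1)c1nc(C(F)(F)F)c(C(=O)N/N=C/c2cccc(C(F)(F)F)c2)s1` share one core and differ only in where the trifluoromethyl sits on the phenyl ring attached to the carbon with a double bond to nitrogen. In a functional assay on A549 cells (Homo sapiens) for inhibition, read by MTT assay, with a stated time of 72 h (a lower number here means a stronger inhibitor, a higher number a weaker inhibitor), compound 1 gives 6.07 ug/mL, compound 2 gives 6.96 ug/mL and compound 3 gives 6.52 ug/mL. Compound 2 stands apart from neither neighbour: the steps of a 1.1-fold higher number from compound 1 to compound 2 (0.06 log units; within the scatter) and a 1.1-fold lower number from compound 2 to compound 3 (0.03 log units; within the scatter) both lie within the scatter, as does a 1.1-fold higher number from compound 1 to compound 3 (0.03 log units; within the scatter). Compound 4 `CN(C(=O)NC(=O)c1c(F)cccc1F)c1nc(C(F)(F)F)c(C(=O)N/N=C/c2ccccc2C(F)(F)F)s1` has not yet been measured and differs from compound 2 on another ring: 2,6-difluorophenyl in place of 3,4-difluorophenyl on a carbonyl carbon. Among the measured compounds shown here, no measured step touches this ring, so the only guide is that every measured swap of position on the other ring stayed within the scatter. On that basis the estimate for compound 4 is 7 ug/mL, with a range from 3.5 ug/mL to 14 ug/mL, which means an expected step of a 1.0-fold higher number from compound 2 to compound 4 (0.00 log units; within the scatter) and no change beyond the scatter.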

Compound 4, half-maximal inhibitory concentration: 17.9 ug/mL
The estimate for compound 4 lay 2.6-fold (0.41 log units) below the measured number; measured number above the stated range.
By their numbers in this assay, from the lowest: compounds 1, 3 and 2 (each within the scatter of the next); then compound 4.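

Moving the two fluorines on the ring attached to the carbonyl carbon gives, in this assay, a 2.6-fold higher number from compound 2 to compound 4 (0.41 log units; beyond the scatter) and so a weaker inhibitor, the only step shown that lies beyond the scatter. Compound 2 and compound 4 hold the same atoms, joined differently, so the placing of the fluorines on this ring is all that separates them. This ring therefore registers a change of position, whereas the trifluoromethyl swaps on the other ring did not, and no measurement at hand offers an explanation.

As far as these compounds go, only compound 4 carries the 2,6-difluorophenyl group, so it remains open whether this change would have the same size with the trifluoromethyl placed as in compound 1 or compound 3. The compounds shown also leave open how this position would respond to an unsubstituted phenyl, a 2,6-dichlorophenyl or a 4-methoxyphenyl group.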